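The source may hold more compounds than are shown below. What is called first, only, known or untested is meant among the compounds shown, and "the series" means these compounds.

Measured compounds:
compound 1, `C=CC1=C(C(=O)Nc2ccc(OCC)cc2)C(c2ccc(OC)cc2)OC1`, 17600 nM
compound 2, `C=CC1=C(C(=O)Nc2ccc(OCC)cc2)C(c2ccc(F)cc2)OC1`, "not active" (no number reported)

Going by the values given here, in a functional assay on A549 cells (Homo sapiens) for cytotoxicity, read by MTT assay, with a stated time of 24 h (a higher number here means a weaker inhibitor, a lower number a stronger inhibitor), compound 1 gives 17600 nM, the only number in the set. Among the compounds with values here, compound 2 is reported in this assay as "not active" (no number reported) with no number attached, so no step to compound 1 can be sized. Compound 3, `C=CC1=C(C(=O)NCC(C)C)C(c2ccc(OC)cc2)OC1`, differs from compound 1 by isobutyl in place of 4-ethoxyphenyl on an amide-type nitrogen. Within the data shown here, with no measured step of this kind available, compound 3 is expected to stay near compound 1, the step of a 1.4-fold higher number from compound 1 to compound 3 (0.15 log units; within the scatter) lying within the scatter or slightly weaker. The estimate for compound 3 is 25000 nM, ranging from 8000 nM to 80000 nM.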

Compound 3, half-maximal inhibitory concentration: > 100000 nM
Compound 3 ended at the assay's limit (the forecaster's own chance of this, stated with the estimate: 35%); middle value at least 4.0-fold (0.60 log units) away from the limit.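

Going by these compounds alone, on the amide-type nitrogen, putting isobutyl in place of 4-ethoxyphenyl gives the first change in the set that can be sized, and in this assay it reads as an at least 5.6-fold higher number from compound 1 to compound 3 (0.75 log units; beyond the scatter). The measurable effect of compound 1 in this assay does not carry over to compound 3 with this single change. Compound 3 stands at a limit and not at a number, so the full size of the step stays unknown: the limit of > 100000 nM in this assay, at which 1 of the 3 values shown sits.

The compounds shown leave open whether the aromatic ring or its ethoxy group accounts for the difference. An unsubstituted phenyl or a benzyl group on the same nitrogen would bear on that question.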